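A few compounds are considered here, and "the series" means these few. Any claim that something is new, unique, unknown or untested is made for them only; others in the source may bear on it.

In a functional assay on Huh-7 cells (Homo sapiens) for antiproliferative activity, read by CCK-8 assay, with a stated time of 72 h (a lower number here means a stronger inhibitor of growth, a higher number a weaker inhibitor of growth), the measured compounds are:

- compound 1 (`CCC1C(=O)N(C)c2cnc(-n3ccc4cc(C(=O)NC(C)C)ccc43)nc2N1c1ccn(C)n1`): 6740 nM
- compound 2 (`CCC1C(=O)N(C)c2cnc(-n3ccc4cc(F)ccc43)nc2N1c1ccn(C)n1`): "not active" (no number reported)
- compound 3 (`CCC1C(=O)N(C)c2cnc(-n3ccc4cc(C(=O)NCC(C)C)ccc43)nc2N1c1ccn(C)n1`): 5070 nM

Among the compounds with values here, compound 3 at 5070 nM and compound 1 at 6740 nM lie within the scatter of each other, and they are the only two numbers available. Within the data shown here, compound 2 has no amide and gives no number, so it offers no measured step.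

Compound 4 (`CCC1C(=O)N(C)c2cnc(-n3ccc4cc(C(=O)NC5CCCC5)ccc43)nc2N1c1ccn(C)n1`) has not yet been measured. It differs from compound 3 by one change, cyclopentyl in place of isobutyl on an amide-type nitrogen and the rest of the structure stays the same.

Among the measured compounds shown here, one measured step bears on this: a 1.3-fold lower number from compound 1 to compound 3 (0.12 log units; within the scatter) for isobutyl in place of isopropyl on that same amide-type nitrogen. That step stays within the scatter. It is a single step, and neither of its groups contains a ring, so it is only a weak guide to cyclopentyl. No step beyond the scatter is therefore expected in this assay for this change, and no direction is favoured.

The estimate means a 1.0-fold lower number from compound 3 to compound 4 (0.01 log units; within the scatter) as the expected step. For compound 4 the expected value is 5000 nM with an estimated range of 2200 nM to 11000 nM for the measurement.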

Compound 4, concentration for 50% growth inhibition: "not active" (no number reported)
Compound 4 has no reported number here, and the estimate cannot be compared.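

In this assay, within the data shown here, compound 4 is reported as "not active" with no number, so no step from compound 3 to compound 4 can be read. No measurement shown offers an explanation for this result. The compounds shown leave open how far compound 4 actually lies from compound 3 in this assay.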